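Methoxymethyl on a Ring Nitrogen and Cell Potency

The source may hold more compounds than are shown below. What is called first, only, known or untested is meant among the compounds shown, and "the series" means these compounds.

Compound 1 `O=c1cc(CC(O)(COCc2ccccc2)COCc2ccccc2)[nH]c(=O)[nH]1` in a functional assay on MIA PaCa-2 cells (Homo sapiens) for antiproliferative activity, read by MTT assay, with a stated time of 72 h (a higher number here means a weaker inhibitor, a lower number a stronger inhibitor), gives > 100000 nM, a limit of the assay.
Compound 2 `COCn1c(CC(O)(COCc2ccccc2)COCc2ccccc2)cc(=O)[nH]c1=O` gives > 100000 nM, also a limit.
Compound 3 `COCn1c(=O)[nH]c(CC(COCc2ccccc2)COCc2ccccc2)c(C)c1=O` gives 27300 nM.

From compound 1 to compound 2 the change is methoxymethyl in place of hydrogen on an aromatic nitrogen. The resulting step that the two limits leave unreadable from compound 1 to compound 2 cannot be read, because both values sit at the limit of > 100000 nM in this assay, at which 2 of the 3 values shown sit. How the core of compound 3 differs from that of compound 1 is not broken down here.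

Compound 4 `COCn1c(CC(COCc2ccccc2)COCc2ccccc2)c(C)c(=O)n(COC)c1=O` differs from compound 3 by methoxymethyl in place of hydrogen on an aromatic nitrogen. This is the same kind of change, but here the place is also meta to a methoxymethyl group and meta to a methyl group. Since the earlier step is unreadable, the expectation rests on compound 3 and its value 27300 nM, and the step of a 1.1-fold higher number from compound 3 to compound 4 (0.04 log units; within the scatter) is expected to be small. Compound 4 is therefore estimated at 30000 nM, between 8000 nM and 100000 nM.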

Compound 4, half-maximal inhibitory concentration: 500 nM
Compound 4: the middle estimate sits 60-fold (1.78 log units) above what was measured; measured number below the stated range.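

In this assay, methoxymethyl in place of hydrogen on an aromatic nitrogen gives a 55-fold lower number from compound 3 to compound 4 (1.74 log units; beyond the scatter), so on this core the change makes a large difference. The same change on the core of compound 1 cannot be read, because both values there are limits of the assay, not numbers: the limit of > 100000 nM in this assay, at which 2 of the 4 values shown sit. This single readable step therefore does not show whether the gain carries from one core to another, nor does it explain why the gain appears.

From the compounds shown here alone, it remains open whether an ethyl group or a longer chain such as methoxyethyl on that nitrogen would give a step of similar size. An amine or a carboxylic acid at the same place is also an open case.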